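Chloro gives way to isopropyl in compound 4

A few compounds are considered here, and "the series" means these few. Any claim that something is new, unique, unknown or untested is made for them only; others in the source may bear on it.

In a functional assay on HepG2 cells (Homo sapiens) for antiproliferative activity, read by MTT assay, with a stated time of 48 h (a lower number here means a stronger inhibitor, a higher number a weaker inhibitor), compound 3 `O=C(/C=C/c1ccc(/C=C/C(=O)c2ccc(Cl)cc2)o1)NO` gives 6740 nM, compound 2 `O=C(/C=C/c1ccc(/C=C/C(=O)c2ccccc2)o1)NO` gives 12100 nM and compound 1 `O=C(/C=C/c1ccc(/C=C/C(=O)c2cccc(Cl)c2)o1)NO` gives 54500 nM. Compound 3 therefore stands level with compound 2 and well clear of compound 1. Compound 4 `CC(C)c1ccc(C(=O)/C=C/c2ccc(/C=C/C(=O)NO)o2)cc1` brings one change: isopropyl in place of chloro on an aromatic carbon. The nearest evidence is a 1.8-fold lower number from compound 2 to compound 3 (0.25 log units; within the scatter), within the scatter, for chloro in place of hydrogen. The modest steps, a 4.5-fold lower number from compound 1 to compound 2 (0.65 log units; beyond the scatter) and an 8.1-fold lower number from compound 1 to compound 3 (0.91 log units; beyond the scatter), both start from the 3-chlorophenyl group, which the change leaves aside. Among the compounds with values here, no measured compound carries isopropyl, so confidence is limited. The expected step is a 1.2-fold higher number from compound 3 to compound 4 (0.07 log units; within the scatter), staying within the scatter. The estimate for compound 4 is 8000 nM, with an expected range from 3000 nM to 22000 nM.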

Compound 4, half-maximal inhibitory concentration: 35900 nM
Estimate against measurement, compound 4: 4.5-fold (0.65 log units) below, outside the stated range (above it).
By their numbers in this assay, from the lowest: compounds 3 and 2 (each within the scatter of the next); then compounds 4 and 1 (each within the scatter of the next).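

Isopropyl in place of chloro gives a 5.3-fold higher number from compound 3 to compound 4 (0.73 log units; beyond the scatter) and isopropyl in place of hydrogen gives a 3.0-fold higher number from compound 2 to compound 4 (0.47 log units; beyond the scatter) in this assay. Chloro and hydrogen could not be told apart at this position, para to a large group, so isopropyl is the first group here to separate clearly from both, and it does so towards weaker activity. No evidence here explains this rise. Going by these compounds, whether methyl, an amine or a carboxylic acid at this position would stay level with chloro or climb like isopropyl remains open.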